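The source may report more compounds than this note shows. Statements on the series, on what has been measured and on what is new or still open speak of the compounds shown alone.

Working notes on the series. Compound 1 `Cc1cc(F)c(S(C)(=O)=O)cc1C(=O)N=C(N)N` gives in a functional assay for inhibition of sodium/hydrogen exchanger (Oryctolagus cuniculus) (on this read-out higher numbers stand for weaker inhibition and lower numbers for stronger inhibition), a value of 44 nM. Within the data shown here, compound 2 `CCSc1cc(C)c(C(=O)N=C(N)N)cc1S(C)(=O)=O` gives in this assay a value of 5.9 nM, the lowest of the two numbers so far, with compound 1 as its nearest neighbour. The step from these two, ethylsulfanyl in place of fluoro on an aromatic carbon, gave a 7.5-fold lower number from compound 1 to compound 2 (0.87 log units; beyond the scatter). Compound 3 `Cc1cc(OC2CCCCC2)c(S(C)(=O)=O)cc1C(=O)N=C(N)N` is not yet measured. Its difference from compound 2 is cyclohexyloxy in place of ethylsulfanyl on an aromatic carbon. Among the measured compounds shown here, the only step that bears on this position is the one from compound 1 to compound 2, which shows that a larger group in place of fluoro was accepted there; no step reports an oxygen-linked ring group at that carbon. On that basis compound 3 is expected to stay close to compound 2, with a step of a 1.4-fold higher number from compound 2 to compound 3 (0.13 log units; within the scatter) in this assay that may fall within the scatter. The estimate for compound 3 in this assay is 8 nM, with a range from 2.5 nM to 25 nM.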

Compound 3, half-maximal inhibitory concentration: 37 nM
The estimate for compound 3 lay 4.6-fold (0.67 log units) below the measured number; the whole stated range lies below it.
By their numbers in this assay, from the lowest: compound 2; then compounds 3 and 1 (each within the scatter of the next).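

In this assay, cyclohexyloxy in place of ethylsulfanyl gives a 6.3-fold higher number from compound 2 to compound 3 (0.80 log units; beyond the scatter) and so shows that this aromatic carbon, ortho to a methylsulfonyl group, does not treat every group larger than fluoro alike. Cyclohexyloxy in place of fluoro gives a 1.2-fold lower number from compound 1 to compound 3 (0.08 log units; within the scatter) and so leaves no readable change from fluoro, which means that the stronger inhibition seen with ethylsulfanyl does not extend to this oxygen-linked ring. No measurement bears on why the sulfur-linked chain and the oxygen-linked ring differ here.

The compounds shown leave open whether the oxygen link or the ring accounts for the step from ethylsulfanyl. From the compounds shown here alone, an ethoxy group and a cyclohexylsulfanyl group on this carbon would separate the two, and an amine linker on this carbon remains equally open.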